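The source may hold more compounds than are shown below. What is called first, only, known or untested is meant among the compounds shown, and "the series" means these compounds.

In an assay on CHO cells for displacement of a labelled ligand from adenosine receptor A3 (Homo sapiens), read by scintillation counting, with a stated time of 45 min, tested at 1 uM, in the presence of a further agent that is not named here (on this read-out lower numbers stand for less inhibition and higher numbers for more inhibition at the one concentration tested (going by the name of the read-out)), the measured compounds gave:
compound 1 `CCCn1c(=O)[nH]c2nc(-c3ccc(S(=O)(=O)N4CCN(C)CC4)cc3)[nH]c2c1=O`: 7%
compound 2 `CCCn1c(=O)[nH]c2nc(-c3ccc(S(=O)(=O)N4CCN(c5cccc(Br)c5)CC4)cc3)[nH]c2c1=O`: 27%
compound 3 `CCCn1c(=O)c2[nH]c(-c3ccc(S(=O)(=O)N4CCN(c5ccc(Cl)cc5)CC4)cc3)nc2n(CC)c1=O`: 28%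

Compound 2 stands second highest of the three numbers; its value and that of compound 3 lie within the scatter of each other, while compound 1 sits well below it. Compound 4 `CCCn1c(=O)[nH]c2nc(-c3ccc(S(=O)(=O)N4CCN(Cc5ccc(Br)c(F)c5)CC4)cc3)[nH]c2c1=O` differs from compound 2 by 4-bromo-3-fluorobenzyl in place of 3-bromophenyl on an amine nitrogen in a ring on an amine nitrogen in a ring. Among the measured compounds shown here, no measured step swaps one such aromatic group for another. For the measured compounds named here, the only step that touches this position, a number 20 percentage points higher from compound 1 to compound 2 (beyond the scatter), replaced methyl with an aromatic group and raised the number; compound 4 keeps an aromatic group there, so no step beyond the scatter is expected in this assay. Compound 4 is therefore estimated at 26%, a range of 10% to 45%, meaning an expected step of a number 1 percentage points lower from compound 2 to compound 4 (within the scatter).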

Compound 4, a percentage reported as inhibition, at one concentration (the size of the read-out at that concentration, not a potency): 27%
Compound 4: middle estimate off by 1 percentage points, on the low side; the measured number falls inside the stated range.
By their numbers in this assay, from the lowest: compound 1; then compounds 2, 4 and 3 (each within the scatter of the next).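

In this assay, the change from 3-bromophenyl to 4-bromo-3-fluorobenzyl gives no change at the digits printed from compound 2 to compound 4 (within the scatter), so on this ring amine nitrogen, an aromatic ring attached through an extra carbon reads the same as one attached directly. The rise over methyl also recurs with this second aromatic group, as a number 20 percentage points higher from compound 1 to compound 4 (beyond the scatter). The data shown offer no explanation for this match. Still open, going by these compounds, is whether a cyclohexyl ring or a longer alkyl chain at this position would give a similar number, and whether a carboxylic acid on the benzyl ring would change it.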